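The source may report more compounds than this note shows. Statements on the series, on what has been measured and on what is new or still open speak of the compounds shown alone.

Measured compounds:
compound 1 `Cn1cc(C2=C(c3nn(CCn4ccnc4)c4ncccc34)C(=O)NC2=O)c2ccccc21`: > 100000 nM
compound 2 `Cn1cc(C2=C(c3n[nH]c4ncccc34)C(=O)N(c3cccc4ccccc34)C2=O)c2ccccc21`: > 100000 nM
compound 3 `Cn1cc(C2=C(c3nn(CCCn4ccnc4)c4ncccc34)C(=O)N(c3ccccc3)C2=O)c2ccccc21`: 34800 nM

In a functional assay on SMMC-7721 cells (Homo sapiens) for antiproliferative activity, read by MTT assay, with a stated time of 48 h (a lower number here means a stronger inhibitor, a higher number a weaker inhibitor), compound 1 gives > 100000 nM, which is a limit of the assay rather than a number. Compound 2 gives > 100000 nM, again only a limit. Going by the values given here, compound 3 gives 34800 nM, the single plain number among the three. The other two values sit at the limit of > 100000 nM in this assay, at which 2 of the 3 values shown sit. Compound 4 `Cn1cc(C2=C(c3nn(CCCCn4ccnc4)c4ncccc34)C(=O)N(c3ccccc3)C2=O)c2ccccc21` has not yet been measured; it differs from compound 3 by (1H-imidazol-1-yl)methyl in place of 1H-imidazol-1-yl on a saturated chain carbon, three bonds along the chain from an aromatic nitrogen. The 1H-imidazol-1-yl ring is kept and the chain carrying it grows by one link. Such a change is expected to shift the result little, if at all, beyond the usual scatter, with no clear direction. Compound 4 is therefore estimated at 35000 nM, between 12000 nM and 100000 nM. The expected step is a 1.0-fold higher number from compound 3 to compound 4 (0.00 log units; within the scatter).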

Compound 4, half-maximal inhibitory concentration: 1760 nM
The estimate for compound 4 lay 20-fold (1.30 log units) above the measured number; the whole stated range lies above it.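

With the 1H-imidazol-1-yl ring kept, going from 3-(1H-imidazol-1-yl)propyl to 4-(1H-imidazol-1-yl)butyl gives a 20-fold lower number from compound 3 to compound 4 (1.30 log units; beyond the scatter) in this assay from a single added chain link. Chain length alone can therefore move this result well beyond the scatter, so this position is far more sensitive than a small change suggests. Nothing measured here explains why the added link matters so much. As far as these compounds go, one step makes no trend, so it remains open whether a longer chain, such as a five-carbon one, would lower the number further. Also open, from the compounds shown here alone, is whether an amine could stand in place of the 1H-imidazol-1-yl ring.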